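Chloro for methyl on the pyrazole of compound 3

A few compounds are considered here, and "the series" means these few. Any claim that something is new, unique, unknown or untested is made for them only; others in the source may bear on it.

Measured so far:
compound 1, `Cc1nn(CC2(O)COC2)cc1Nc1nc(N)c2c(C#N)c(N3CCC[C@H]3C)n(C)c2n1`, 57 nM
compound 2, `Cc1c(Nc2nc(N)c3c(C#N)c(N4CCC[C@H]4C)n(C)c3n2)cnn1[C@@H]1CCOC1`, 20 nM
compound 3, `Cc1nn(C)cc1Nc1nc(N)c2c(C#N)c(N3CCC[C@H]3C)n(C)c2n1`, 38 nM

In an assay on isolated protein for inhibition of Leucine-rich repeat serine/threonine-protein kinase 2 (Homo sapiens), read by TR-FRET and LanthaScreen, with stated times of 50 min and 30 min, in the presence of a further agent that is not named here (on this read-out higher numbers stand for weaker inhibition and lower numbers for stronger inhibition), compound 3 gives 38 nM, the second highest of the three numbers. Its nearest neighbour is compound 1 with 57 nM; compound 2, with 20 nM, lies a little further off, though both gaps fall within the scatter, so no order among the three can be read from them.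

Compound 4, `C[C@@H]1CCCN1c1c(C#N)c2c(N)nc(Nc3cn(C)nc3Cl)nc2n1C`, keeps the shared core of compound 3 and changes only the pyrazole: chloro in place of methyl on an aromatic carbon.

For the measured compounds named here, the one measured step, a 1.5-fold lower number from compound 1 to compound 3 (0.18 log units; within the scatter), alters the group on the pyrazole nitrogen rather than the carbon substituent, so it bears on the present change only loosely, and it too stayed within the scatter. Going by the values given here, no measured pair shows what a chloro in place of a methyl does at this carbon. The expectation therefore rests on the flatness seen so far: the step of a 1.1-fold higher number from compound 3 to compound 4 (0.02 log units; within the scatter) is expected to stay within the scatter, in neither direction with confidence.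

Compound 4 is accordingly estimated at 40 nM, with a range from 15 nM to 110 nM.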

Compound 4, half-maximal inhibitory concentration: 34 nM
For compound 4 the middle estimate is 1.2-fold (0.07 log units) above the measured one; measured number inside the range.
By their numbers in this assay, from the lowest: compounds 2, 4, 3 and 1 (each within the scatter of the next, the first and the last beyond it).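

In this assay, for the compounds shown here, the pyrazole carbon next to the ring atom that bears a large group is changed for the first time, and chloro in place of methyl gives a 1.1-fold lower number from compound 3 to compound 4 (0.05 log units; within the scatter) with no difference that this read-out can separate from scatter. The earlier step touched only the group on the ring nitrogen, so this pair adds that, for this exchange of one heavy atom for another, the number also holds level when the substituent on the aromatic carbon changes, at least with a methyl on the ring nitrogen. Nothing on hand says why the two compounds read alike.

The compounds shown leave open whether this position stays as flat for anything larger than a single atom, such as methoxy, cyclopropyl or trifluoromethyl, or for a plain hydrogen there. Going by these compounds alone, they also leave open whether chloro at this carbon reads the same when the methyl on the ring nitrogen gives way to the 3-hydroxyoxetan-3-yl-bearing chain of compound 1, since the two changes appear together in no compound here.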